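The source may hold more compounds than are shown below. What is called first, only, known or untested is meant among the compounds shown, and "the series" means these compounds.

Of the compounds shown here, three of one shared core have been measured, and they differ from one another only in configuration as drawn. In an assay on a subcellular fraction from brain for inhibition of sodium-dependent dopamine transporter (Rattus norvegicus) (on this read-out lower numbers stand for stronger inhibition and higher numbers for weaker inhibition), compound 1 `COC(=O)[C@H]1CN(C)CC[C@@H]1c1ccc2ccccc2c1` gives 947 nM. Compound 2 `COC(=O)[C@@H]1CN(C)CC[C@H]1c1ccc2ccccc2c1` gives 87 nM in this assay, and compound 3 `COC(=O)[C@H]1CN(C)CC[C@H]1c1ccc2ccccc2c1` gives 271 nM. Compound 2 therefore stands lowest of the three numbers: an 11-fold lower number from compound 1 to compound 2 (1.04 log units; beyond the scatter), a 3.5-fold lower number from compound 1 to compound 3 (0.54 log units; beyond the scatter) and a 3.1-fold higher number from compound 2 to compound 3 (0.49 log units; beyond the scatter), each beyond the scatter, and each resting only on a change of configuration the fact that compounds 1 and 2 differ only in the configuration as drawn the fact that compounds 1 and 3 differ only in the configuration as drawn (the fact that compounds 2 and 3 differ only in the configuration as drawn).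

Compound 4 `COC(=O)[C@@H]1CNCC[C@H]1c1ccc2ccccc2c1` keeps the configuration of compound 2 and differs from it by hydrogen in place of methyl on an amine nitrogen in a ring. For the measured compounds named here, none of the measured steps concern such a change; all three are inversions of stereocentres, so they give no guide to the size or direction of this one. With nothing in the data pointing either way, the step from compound 2 to compound 4 in this assay is expected to stay within the scatter, a 1.3-fold higher number from compound 2 to compound 4 (0.10 log units; within the scatter). Compound 4 is accordingly estimated at 110 nM in this assay, within a range from 40 nM to 300 nM.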

Compound 4, inhibition constant: 90 nM
Estimate against measurement, compound 4: 1.2-fold (0.09 log units) above; the range from low to high includes it.
By their numbers in this assay, from the lowest: compounds 2 and 4 (each within the scatter of the next); then compound 3; then compound 1.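

Hydrogen in place of methyl on the amine nitrogen in a ring, with the configuration of compound 2 kept, gives a 1.0-fold higher number from compound 2 to compound 4 (0.01 log units; within the scatter) in this assay. For the compounds shown here, this is the first step at this position and the first that is not an inversion of a stereocentre, and unlike the three inversions it stays within the scatter, so in this configuration the read-out does not separate methyl from hydrogen on this nitrogen. None of the facts at hand about configuration bears on this change, so nothing here accounts for the result.

The compounds shown do not tell whether the same holds in the configurations of compound 1 or compound 3. They also leave open what a larger group on this nitrogen, such as an ethyl or benzyl group or a longer chain, would do.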